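This account rests on a few compounds, and the source may have more. Where it says the series, first, only, none or still open, it means among the compounds named here.

Working notes on the series. Compound 2 `CC1CC/C(=N\Nc2ccc(O)cc2)c2ncc(C(=O)O)c(=O)n21` stands only at a limit in a functional assay on the whole organism for inhibition, with Rattus norvegicus as the target; a lower number here means that less compound is needed, a higher number that more compound is needed for the effect: compound 2 gives > 100 umol/kg, a limit of the assay and not a number. Compound 1 `CC1CC/C(=N\Nc2ccccc2F)c2ncc(C(=O)O)c(=O)n21` likewise gives in this assay the value > 1000 umol/kg, again a limit. The step that the two limits leave unreadable from compound 1 to compound 2 is therefore unreadable, as the two limits leave no room for a size. Compound 3 `COc1ccccc1N/N=C1\CCC(C)n2c1ncc(C(=O)O)c2=O` is not yet measured; its change from compound 2 is 2-methoxyphenyl in place of 4-hydroxyphenyl on an amine nitrogen. For the measured compounds named here, the only measured step bearing on this site is the one from compound 1 to compound 2, and it tells nothing about size or direction; what is known is the limit of > 100 umol/kg in this assay, at which 1 of the 2 values shown sits, for compound 2 and the limit of > 1000 umol/kg in this assay, at which 1 of the 2 values shown sits, for compound 1. No step beyond the scatter can be expected from this. For compound 3 the expected value in this assay is estimated at 300 umol/kg, in the range 100 umol/kg to 1000 umol/kg. The step that the limit leaves unreadable from compound 2 to compound 3 is thus expected to remain within the scatter.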

Compound 3, dose for 50% inhibition: > 1000 umol/kg
Compound 3 ended at the assay's limit; the forecaster's own chance of this, stated with the estimate: 70%; middle value at least 3.3-fold (0.52 log units) from the limit.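

For the compounds shown here, compound 3 gives > 1000 umol/kg in this assay, a limit and not a number, and no step from compound 1 or compound 2 to compound 3 can be read. As far as these compounds go, whether the groups on the amine nitrogen of compound 1, compound 2 and compound 3 differ in effect stays open.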